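Removing one fluoro from the benzyl ether of compound 2

The source may report more compounds than this note shows. Statements on the series, on what has been measured and on what is new or still open speak of the compounds shown alone.

Of the compounds shown here, three sharing one core have been measured in an assay on V79MZh11B2 cells for inhibition of cytochrome P450 11B2, mitochondrial (Homo sapiens), read by HPLC, with a stated time of 25 min; a higher number here means a weaker inhibitor, a lower number a stronger inhibitor. Compound 1 `COc1ccc(COc2ccc3c(Cn4ccnc4)cc(=O)oc3c2)cc1OC` gives 82 nM, compound 3 `CC(C)Oc1ccc(COc2ccc3c(Cn4ccnc4)cc(=O)oc3c2)cc1` gives 82 nM, and compound 2 `O=c1cc(Cn2ccnc2)c2ccc(OCc3cc(F)cc(F)c3)cc2o1` gives 200 nM. Compound 2 carries the highest number of the three; its nearest neighbour is compound 1, and both compound 1 and compound 3 sit lower by a margin beyond the scatter, so compound 2 reads as the weakest inhibitor of this set. Compound 1 and compound 3 cannot be ordered against each other, since their values coincide.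

Compound 4 `O=c1cc(Cn2ccnc2)c2ccc(OCc3cccc(F)c3)cc2o1` has not been measured in this assay. Against compound 2 it differs in one place: hydrogen in place of fluoro on an aromatic carbon. No measured pair in the series isolates this change, so nothing shown here fixes its size. Compound 1 and compound 3, the two with lower numbers, are substituted differently on the benzyl group and give no direct guidance. The expected step of a 1.3-fold lower number from compound 2 to compound 4 (0.12 log units; within the scatter) is therefore small, plausibly within the scatter, with a slight lean toward a lower number. Compound 4 is expected to give 150 nM in this assay, with a range from 70 nM to 350 nM.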

Compound 4, half-maximal inhibitory concentration: 200 nM
Beside the measured number, compound 4's estimate is 1.3-fold (0.12 log units) below it, within the range that was stated.
By their numbers in this assay, from the lowest: compounds 1 and 3 (each within the scatter of the next); then compounds 2 and 4 (each within the scatter of the next).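

In this assay, going by these compounds alone, the pair reads no change at the digits printed from compound 2 to compound 4 (within the scatter), the first step that isolates a single change: hydrogen in place of fluoro on an aromatic carbon, meta to a fluoro group and meta to a large group. Going from 3,5-difluorobenzyl to 3-fluorobenzyl therefore leaves no readable mark on this read-out, so on this core one of the two fluoro groups can be exchanged for hydrogen with no change beyond the scatter. No accompanying measurement bears on this result, and the pair gives a size for the step but no explanation of it.

Still open, as far as these compounds go, is whether the remaining fluoro can also be exchanged for hydrogen, giving a plain benzyl ether, or whether the flat reading holds only while one fluoro stays on the ring. Also open, from the compounds shown here alone, is how a chloro, a trifluoromethyl, a nitrile or an amine would read on the same aromatic carbon, since a single exchange for hydrogen says nothing about larger groups there.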